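The compounds below may be only part of what the source reports. "The series", "measured", "known", "first", "only" and "open" are said of these compounds alone.

Working notes on the series. Three compounds share one core and differ only in the side chain on the amino acid benzyl ester. Compound 1 `C[C@@H](O)[C@H](NC(=O)CN(c1nc(Cl)nc2[nH]cnc12)C1CC1)C(=O)OCc1ccccc1` gives 21.9% in a functional assay on the whole organism (Tail, strain ICR) with Mus musculus as the target, in the tail flick test, with a stated time of 30 min, at a dose of 25 umol/kg by the oral route; a higher number here means a stronger effect of the compound at the dose given, a lower number a weaker effect. Compound 2 `O=C(CN(c1nc(Cl)nc2[nH]cnc12)C1CC1)N[C@@H](CCC(=O)OCc1ccccc1)C(=O)OCc1ccccc1` gives 52.8%, and compound 3 `NCCCC[C@H](NC(=O)CN(c1nc(Cl)nc2[nH]cnc12)C1CC1)C(=O)OCc1ccccc1` gives 26.1%.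

Among these three numbers compound 3 stands second highest. Its nearest neighbour is compound 1, and the gap between them, a number 4.2 percentage points higher from compound 1 to compound 3 (within the scatter), lies within the scatter, so no order between the two can be claimed. Compound 2 is the furthest, and a number 26.7 percentage points lower from compound 2 to compound 3 (beyond the scatter) is beyond the scatter.

Compound 4 `CC(C)C[C@H](NC(=O)CN(c1nc(Cl)nc2[nH]cnc12)C1CC1)C(=O)OCc1ccccc1` differs from compound 3 by isopropyl in place of 3-aminopropyl on a saturated chain carbon, two bonds along the chain from an amide-type nitrogen and a carbonyl carbon. Among the measured compounds shown here, no measured step matches this change. For the measured compounds named here, two steps touch the same position: a number 4.2 percentage points higher from compound 1 to compound 3 (within the scatter), within the scatter, and a number 30.9 percentage points higher from compound 1 to compound 2 (beyond the scatter), large. Together they show that this position can move the number a long way or not at all, and the only large move seen, to compound 2, went upward. A small to modest rise in this assay is therefore expected for compound 4, with a wide range. The expected step is a number 8.9 percentage points higher from compound 3 to compound 4 (within the scatter). Compound 4 is estimated at 35%, within a range from 15% to 58%.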

Compound 4, a percentage reported as activity, at one dose (the size of the read-out at that dose, not a potency): 33.9%
Compound 4: middle estimate off by 1.1 percentage points, on the high side; low and high end bracket the measured number.
By their numbers in this assay, from the lowest: compounds 1, 3 and 4 (each within the scatter of the next, the first and the last beyond it); then compound 2.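

In this assay, the change from an amine-bearing chain to a purely carbon one, a number 7.8 percentage points higher from compound 3 to compound 4 (within the scatter), does not separate the two compounds, so the terminal amine of 3-aminopropyl is not shown to matter for this read-out at this position. The same isopropyl end does separate compound 4 from the hydroxyl-bearing side chain, since a number 12 percentage points higher from compound 1 to compound 4 (beyond the scatter) is a modest step, the first beyond the scatter from compound 1 that does not involve the benzyl ester side chain, although compound 3 remains within the scatter of both. Among the compounds shown here, it also leaves that ester-bearing side chain apart, with a number 18.9 percentage points lower from compound 2 to compound 4 (beyond the scatter) as a modest step, so compound 2 is still the only compound clear of the other three.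

The compounds shown leave open whether the higher number of compound 2 depends on the terminal benzyl ester of its side chain, which a free carboxylic acid at that chain end or a benzyl side chain would address, and whether a longer unbranched carbon chain would follow isobutyl. Nothing shown gives a measured cause for any of these steps.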